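Trimethoxystyryl ketone series: anilino ring swap to dichlorophenyl

This account rests on a few compounds, and the source may have more. Where it says the series, first, only, none or still open, it means among the compounds named here.

Going by the values given here, compound 1 `COc1cc(/C=C/C(=O)c2sc(Nc3ccccc3C)nc2C)cc(OC)c1OC` is the only member of this set with a numerical result in a functional assay on NCI-H460 cells (Homo sapiens) for cytotoxicity, read by MTT assay (on this read-out higher numbers stand for weaker inhibition and lower numbers for stronger inhibition), where compound 1 gives 6320 nM. The two other measured members sit at the assay limit. Compound 2 `Cc1nc(Nc2cccc(Cl)c2)sc1C(=O)/C=C/c1ccc(Cl)cc1` reaches only the limit of > 25000 nM in this assay. Compound 3 `Cc1cccc(Nc2nc(C)c(C(=O)/C=C/c3ccccc3Cl)s2)c1` likewise stops at the limit of > 25000 nM in this assay. Among the compounds with values here, compound 1 therefore stands alone as the one compound with a number, and the only hard fact about the rest of the set is the limit of > 25000 nM in this assay, at which 2 of the 3 values shown sit. Within the data shown here, no pair among the measured compounds differs in a single place, so no measured step is available to lean on.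

Compound 4 `COc1cc(/C=C/C(=O)c2sc(Nc3ccc(Cl)c(Cl)c3)nc2C)cc(OC)c1OC` is the next candidate. Relative to compound 1 the change is 3,4-dichlorophenyl in place of 2-methylphenyl on a nitrogen on an aromatic ring. The shared core and the trimethoxy-bearing styryl ketone of compound 1 are kept. Since compound 1 is the sole numerical anchor and the two chlorine-bearing analogues give only limits, a modest weakening rather than a gain is the expectation here, with the possibility of a limit kept in view. For compound 4 the estimate in this assay is 9000 nM, within 3000 nM to 25000 nM. The expected step is a 1.4-fold higher number from compound 1 to compound 4 (0.15 log units; within the scatter).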

Compound 4, half-maximal inhibitory concentration: > 25000 nM
Compound 4 gave a limit, no number; the forecaster's own chance of this, stated with the estimate: 25%; at least 2.7-fold (0.44 log units) between middle value and limit.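

Going by these compounds alone, compound 4 gives the first single-place comparison: with the shared core and the trimethoxy-bearing styryl ketone kept, 3,4-dichlorophenyl in place of 2-methylphenyl on a nitrogen on an aromatic ring brings an at least 3.9-fold higher number from compound 1 to compound 4 (0.59 log units; beyond the scatter) in this assay. As far as these compounds go, the entry for compound 4 is a limit and not a number, so the step can be read only as a minimum and its full size stays unknown. The earlier compounds could not isolate this position, and the pair now shows that the change here is enough on its own to turn the number of compound 1 into a limit, which leaves compound 1 as the only number in the set: the limit of > 25000 nM in this assay, at which 3 of the 4 values shown sit.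

The compounds shown do not separate the loss of the 2-methylphenyl group from the arrival of the 3,4-dichlorophenyl group, and they say nothing about any single-place change elsewhere on compound 1. A phenyl ring bearing a single chlorine, a methoxy group or an amine at this nitrogen would show whether this position can carry anything other than the 2-methylphenyl group and still give a number.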